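One Fluoro Substitution on Compound 2

This account rests on a few compounds, and the source may have more. Where it says the series, first, only, none or still open, it means among the compounds named here.

Compound 1 `Cc1[nH]c2ccccc2c1C1=CCC(NC(=O)c2ccc(OCC(=O)NO)cc2)CC1` and compound 2 `Cc1[nH]c2ccccc2c1C1=CCC(NCc2ccc(OCC(=O)NO)cc2)CC1` are the two compounds measured in a functional assay on HCT-116 cells (Homo sapiens) for antiproliferative activity, with a stated time of 72 h; a higher number here means a weaker inhibitor, a lower number a stronger inhibitor. Compound 1 reads > 5000 nM, which is a limit of the assay and not a number. Among the measured compounds shown here, compound 2 gives 184 nM, the only exact number so far. Compound 3 `Cc1[nH]c2ccccc2c1C1=CCC(NCc2ccc(OCC(=O)NO)cc2F)CC1` differs from compound 2 by one change: fluoro in place of hydrogen on an aromatic carbon. For the measured compounds named here, no measured step shows what fluoro in place of hydrogen on an aromatic carbon does here. The expected step of a 1.1-fold lower number from compound 2 to compound 3 (0.03 log units; within the scatter) is small, with no size beyond the usual scatter and no firm direction. In this assay compound 3 is estimated at 170 nM, with an expected range of 65 nM to 450 nM.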

Compound 3, half-maximal inhibitory concentration: 99 nM
Beside the measured number, compound 3's estimate is 1.7-fold (0.23 log units) above it; low and high end bracket the measured number.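

Fluoro in place of hydrogen on this aromatic carbon, ortho to a large group and meta to the (hydroxycarbamoyl)methoxy group, gives a 1.9-fold lower number from compound 2 to compound 3 (0.27 log units; within the scatter) in this assay. Among the compounds shown here, this is the first measured step at this position, and it shows that the ring carbon takes the fluorine with no loss of activity beyond the scatter. Nothing shown here gives a cause for this step.

From the compounds shown here alone, whether chloro, methoxy or an amine at the same carbon would read alike remains open. So does the effect of fluoro on the other carbons of this ring.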